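Swapping Phenylsulfonyl for Benzoyl on a Shared Core

The compounds below may be only part of what the source reports. "The series", "measured", "known", "first", "only" and "open" are said of these compounds alone.

Compound 1, `COc1ccc(-c2[nH]c3ccccc3c2/C=C(\C#N)S(=O)(=O)c2ccccc2)cc1`, gives 1200 nM in a functional assay on Malme-3M cells (Homo sapiens) for inhibition, read by sulforhodamine B assay, with a stated time of 48 h; a lower number here means a stronger inhibitor of growth, a higher number a weaker inhibitor of growth.
Compound 2, `COc1ccc2[nH]c(-c3ccccc3)c(/C=C(\C#N)S(=O)(=O)c3ccccc3)c2c1`, gives 19400 nM in this assay.
Compound 3, `N#C/C(=C\c1c(-c2ccccc2)[nH]c2ccccc12)S(=O)(=O)c1ccccc1`, gives 8400 nM in this assay.

Among these three numbers, compound 3 stands second highest: compound 2 is its nearest neighbour and compound 1 lies furthest from it. Both measured steps concern a methoxy group: a 7.0-fold higher number from compound 1 to compound 3 (0.85 log units; beyond the scatter), and a 2.3-fold lower number from compound 2 to compound 3 (0.36 log units; beyond the scatter). Each is a modest change beyond the scatter, and the two point in opposite directions.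

Compound 4, `N#C/C(=C\c1c(-c2ccccc2)[nH]c2ccccc12)C(=O)c1ccccc1`, has not yet been measured. It differs from compound 3 in one place: benzoyl in place of phenylsulfonyl on a double-bonded chain carbon bound to a double-bonded chain carbon and a triple-bonded carbon. The sulfonyl link to the phenyl ring is thus replaced by a carbonyl link. Neither measured step touches this part of the molecule; both alter a methoxy on an aromatic ring while the phenylsulfonyl group is kept in all three compounds. Within the data shown here, no measured step therefore bears on this change, and the numbers at hand give no basis for predicting a shift in either direction. For compound 4 the expected step is no change at the digits printed from compound 3 to compound 4 (within the scatter), not beyond the usual scatter, though with wide uncertainty. Compound 4 is estimated at 8400 nM in this assay, within a range from 2500 nM to 28000 nM.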

Compound 4, concentration for 50% growth inhibition: 12300 nM
The estimate for compound 4 lay 1.5-fold (0.17 log units) below the measured number; low and high end bracket the measured number.
By their numbers in this assay, from the lowest: compound 1; then compounds 3, 4 and 2 (each within the scatter of the next, the first and the last beyond it).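

Among these compounds, replacing phenylsulfonyl with benzoyl on a double-bonded chain carbon bound to a double-bonded chain carbon and a triple-bonded carbon gives, in this assay, a 1.5-fold higher number from compound 3 to compound 4 (0.17 log units; within the scatter), the first reading at this place, since the earlier steps changed only a methoxy on an aromatic ring. The group that enters has no sulfur, one heavy atom fewer and one hydrogen-bond acceptor fewer, yet the two compounds stay within the scatter of each other, so with no methoxy present, the phenylsulfonyl group can give way to benzoyl without a readable change in this assay. No measurement here explains why the two groups read alike.

This single pair leaves open whether benzoyl would read the same with the methoxy placement of compound 1, which has the lowest number of the series, or that of compound 2, whose number lies well above it. It also leaves open whether the phenyl ring itself matters at this place, as a carboxylic acid or a simple amide there, with no phenyl ring attached, would test.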